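The compounds below may be only part of what the source reports. "The series", "measured", "known", "first", "only" and "open" are said of these compounds alone.

Series notes. The shared core of compound 1 `COC(=O)C1=C(C)NC(C)=C(C(=O)OC)C1c1csc(-c2ccc(Cl)cc2)n1` carries two methyl esters; in an assay on isolated protein for antagonist activity at Voltage-dependent L-type calcium channel subunit alpha-1C (Cavia porcellus), with a stated time of 15 min (on this read-out lower numbers stand for stronger inhibition and higher numbers for weaker inhibition), compound 1 gives 4430 nM. Compound 2 `CC1=C(C(=O)OC(C)c2ccccc2)C(c2csc(-c3ccc(Cl)cc3)n2)C(C(=O)OC(C)c2ccccc2)=C(C)N1` carries 1-phenylethyl on both ester oxygens, and in this assay compound 2 gives 400000 nM. Compound 3 `COC(=O)C1=C(C)NC(C)=C(C(=O)OC(C)(C)C)C1c1csc(-c2ccc(Cl)cc2)n1` keeps one methyl ester and has tert-butyl on the other; in this assay compound 3 gives 46000 nM, the second highest of the three numbers, with compound 2 as its nearest neighbour and compound 1 furthest away. Among the compounds with values here, the only single-point step among the measured compounds, a 10-fold higher number from compound 1 to compound 3 (1.02 log units; beyond the scatter), is large.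

Compound 4 `COC(=O)C1=C(C)NC(C)=C(C(=O)OC(C)c2ccccc2)C1c1csc(-c2ccc(Cl)cc2)n1` differs from compound 3 in one place: 1-phenylethyl in place of tert-butyl on an oxygen next to a carbonyl group. Within the data shown here, no measured step covers this exact exchange. What bears on it: the step of a 10-fold higher number from compound 1 to compound 3 (1.02 log units; beyond the scatter) shows that replacing methyl with tert-butyl on that oxygen raised the number sharply, and compound 2, with 1-phenylethyl on both oxygens, stands higher than compound 1. Compound 4 keeps one methyl ester, so its number in this assay is expected to lie between the numbers of compound 3 and compound 2. The step of a 1.3-fold higher number from compound 3 to compound 4 (0.12 log units; within the scatter) is expected to be modest, upward if anything. Compound 4 is therefore estimated at 60000 nM, with a range from 15000 nM to 250000 nM.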

Compound 4, half-maximal inhibitory concentration: 7620 nM
For compound 4 the middle estimate is 7.9-fold (0.90 log units) above the measured one, outside the stated range (below it).
By their numbers in this assay, from the lowest: compounds 1 and 4 (each within the scatter of the next); then compound 3; then compound 2.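

At this ester oxygen, the number in this assay does not follow the count of heavy atoms in the group: 1-phenylethyl, with 8 heavy atoms against 4 for tert-butyl, gives the lower number (a 6.0-fold lower number from compound 3 to compound 4 (0.78 log units; beyond the scatter)), and with the other methyl ester kept it cannot be told apart from the dimethyl ester (a 1.7-fold higher number from compound 1 to compound 4 (0.24 log units; within the scatter)). The very high number of the bis(1-phenylethyl) ester therefore does not carry over to a single 1-phenylethyl group, as restoring methyl on one oxygen shows (a 52-fold lower number from compound 2 to compound 4 (1.72 log units; beyond the scatter)), so the penalty seen with tert-butyl at this position is specific to that group among those shown, and compound 2 goes against any reading that 1-phenylethyl is accepted regardless of the second ester. No evidence on hand accounts for the difference between these groups.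

Still open, from the compounds shown here alone, is which part of 1-phenylethyl is accepted, which benzyl, 2-phenylethyl or isopropyl on the same oxygen would help to separate. Also open, going by these compounds, is how far the second ester can grow while 1-phenylethyl stays on the first, for instance with ethyl or a longer chain in place of the remaining methyl.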